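The compounds below may be only part of what the source reports. "The series", "measured", "known", "first", "only" and "open" are said of these compounds alone.

Three compounds share one core and have been measured in a functional assay on MCF7 cells (Homo sapiens) for antiproliferative activity, read by MTT assay, with a stated time of 48 h; a higher number here means a weaker inhibitor, a lower number a stronger inhibitor:

compound 1 `O=C(Nc1cccc(/C=C/C(=O)c2nc3ccccc3[nH]2)c1)c1ccccc1` gives 11200 nM
compound 2 `O=C(/C=C/c1cccc(NC(=O)c2ccccc2Br)c1)c1nc2ccccc2[nH]1` gives 4520 nM
compound 3 `COc1cccc(C(=O)Nc2cccc(/C=C/C(=O)c3nc4ccccc4[nH]3)c2)c1` gives 17800 nM

Within this small set, compound 1 stands second highest of the three numbers: its nearest neighbour is compound 3, with a difference that is within the scatter, and the furthest is compound 2, with a modest step beyond the scatter.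

Compound 4 `O=C(/C=C/c1cccc(NS(=O)(=O)c2cccc(Cl)c2)c1)c1nc2ccccc2[nH]1` is not yet measured. Against compound 1 the change is (3-chlorophenyl)sulfonyl in place of benzoyl on a nitrogen on an aromatic ring. Going by the values given here, no measured step swaps the benzoyl for a sulfonyl group, so the closest guide is what happens when the aryl ring on that group is decorated. Adding a bromine gave a 2.5-fold lower number from compound 1 to compound 2 (0.39 log units; beyond the scatter); adding a methoxy gave a 1.6-fold higher number from compound 1 to compound 3 (0.20 log units; within the scatter), and between those two compounds the step was a 3.9-fold higher number from compound 2 to compound 3 (0.60 log units; beyond the scatter). Going by these compounds, the entering group in compound 4 carries a chlorine on its ring, which is the change most like the bromine of compound 2, but the change from carbonyl to sulfonyl is untested here.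

On that basis, a modest lowering of the number or no change beyond the scatter is expected, estimated as a 1.6-fold lower number from compound 1 to compound 4 (0.20 log units; within the scatter). Compound 4 is estimated at 7000 nM in this assay, with a range from 2500 nM to 20000 nM.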

Compound 4, half-maximal inhibitory concentration: 4160 nM
Estimate against measurement, compound 4: 1.7-fold (0.23 log units) above, within the range that was stated.
By their numbers in this assay, from the lowest: compounds 4 and 2 (each within the scatter of the next); then compounds 1 and 3 (each within the scatter of the next).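

In this assay, the nitrogen on the aromatic ring can carry a sulfonyl group as well as a carbonyl group without loss of activity: putting (3-chlorophenyl)sulfonyl in place of benzoyl gives a 2.7-fold lower number from compound 1 to compound 4 (0.43 log units; beyond the scatter), and putting it in place of (3-methoxyphenyl)carbonyl gives a 4.3-fold lower number from compound 3 to compound 4 (0.63 log units; beyond the scatter). Against the (2-bromophenyl)carbonyl group the same change gives a 1.1-fold lower number from compound 2 to compound 4 (0.04 log units; within the scatter), so two groups with different links and different halogens on their rings cannot be told apart in this assay. The change from benzoyl alters the link and adds the chlorine in a single step, so the share of each cannot be read, and no further data explain the result.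

The compounds shown leave open how a plain phenylsulfonyl group, with no chlorine, would compare with benzoyl, which would separate the effect of the link from that of the halogen. They also leave open whether an aromatic ring is needed on this group at all, which a small methylsulfonyl group on the same nitrogen would test.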